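Working notes: from compound 3 to compound 4

A few compounds are considered here, and "the series" means these few. Any claim that something is new, unique, unknown or untested is made for them only; others in the source may bear on it.

Values in a functional assay on HL-60 cells (Homo sapiens) for antiproliferative activity, with a stated time of 72 h; on this read-out higher numbers stand for weaker inhibition and lower numbers for stronger inhibition:
compound 1 `OC[C@H]1O[C@@H](n2cnc3c(NCc4ccccc4F)ncnc32)[C@H](O)[C@@H]1O`: 3200 nM
compound 2 `OC[C@H]1O[C@@H](n2cnc3c(NCc4ccc(Br)cc4)ncnc32)[C@H](O)[C@@H]1O`: 47400 nM
compound 3 `Cc1ccc(CNc2ncnc3c2ncn3[C@@H]2O[C@H](CO)[C@@H](O)[C@H]2O)cc1`: > 166000 nM, a limit and not a number

Compound 3 stands at the limit of > 166000 nM in this assay, at which 1 of the 3 values shown sits. It therefore offers no exact starting point, and any step from it carries that uncertainty.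

The next structure is compound 4 `COc1ccccc1CNc1ncnc2c1ncn2[C@@H]1O[C@H](CO)[C@@H](O)[C@H]1O`. The change is 2-methoxyphenyl in place of 4-methylphenyl on a saturated chain carbon bound to a nitrogen on an aromatic ring, with 2-methoxyphenyl in place of 4-methylphenyl on a saturated chain carbon bound to a nitrogen on an aromatic ring.

Among the compounds with values here, three measured steps bear on this change. Swapping the aryl group alone gave an at least 51-fold higher number from compound 1 to compound 3 (1.71 log units; beyond the scatter) and a 15-fold higher number from compound 1 to compound 2 (1.17 log units; beyond the scatter), both large. The third, an at least 3.5-fold higher number from compound 2 to compound 3 (0.54 log units; beyond the scatter), is at least modest. Of the measured groups, 2-fluorophenyl is the closest by name to the entering group, and compound 1, which carries it, gives 3200 nM. This is a single example, and fluoro and methoxy are different groups, so only a partial return towards compound 1 is assumed. A large step to a lower number, meaning stronger inhibition, is therefore expected in this assay.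

The estimated step is an at least 11-fold lower number from compound 3 to compound 4 (1.04 log units; beyond the scatter). For compound 4 the expected value is 15000 nM, with an estimated range of 2500 nM to 90000 nM.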

Compound 4, half-maximal inhibitory concentration: 2300 nM
The estimate for compound 4 lay 6.5-fold (0.81 log units) above the measured number; the whole stated range lies above it.
By their numbers in this assay, from the lowest: compounds 4 and 1 (each within the scatter of the next); then compound 2. At a limit, above all of these: compound 3.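

In this assay methoxy in place of fluoro on an aromatic carbon gives a 1.4-fold lower number from compound 1 to compound 4 (0.14 log units; within the scatter) and so places 2-methoxyphenyl level with 2-fluorophenyl at this position, on a saturated chain carbon bound to a nitrogen on an aromatic ring. Among the four compounds, both 2-substituted phenyl groups now separate from both 4-substituted ones, and 2-methoxyphenyl in place of 4-bromophenyl gives a 21-fold lower number from compound 2 to compound 4 (1.31 log units; beyond the scatter) as a second measured step beyond the scatter. 2-Methoxyphenyl in place of 4-methylphenyl gives an at least 72-fold lower number from compound 3 to compound 4 (1.85 log units; beyond the scatter) and the true size of this step stays open because compound 3 is held at a limit and not a number: the limit of > 166000 nM in this assay, at which 1 of the 4 values shown sits.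

The numbering and the substituent still change together in every compound, so a 2-methylphenyl or 2-bromophenyl group would be needed to show whether the 2-substitution alone sets the level of compound 1 and compound 4. As far as these compounds go, how a 4-methoxyphenyl or 4-fluorophenyl group, or an amine such as 2-aminophenyl, would read at this place remains open.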